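Moving Chlorine Within the Chlorophenyl Group of Compound 3

A few compounds are considered here, and "the series" means these few. Any claim that something is new, unique, unknown or untested is made for them only; others in the source may bear on it.

In an assay on MDA-MB-231 cells for binding affinity to C-X-C chemokine receptor type 4 (Homo sapiens), read by immunofluorescence and microscopy, with stated times of 10 min and 30 min (a higher number here means that more compound is needed for the effect, a lower number that less compound is needed), the measured compounds stand as follows:
compound 1 `Cc1ccc(S(=O)(=O)NCc2ccc(CNC(=O)c3ccc(F)cc3)cc2)cc1` gives 1 nM
compound 2 `COc1ccc(C(=O)NCc2ccc(CNS(=O)(=O)c3ccc(C)cc3)cc2)cc1` gives 100 nM
compound 3 `Cc1ccc(S(=O)(=O)NCc2ccc(CNC(=O)c3ccc(Cl)cc3)cc2)cc1` gives 10 nM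

Compound 3 holds the second highest of the three numbers: there is a 10-fold higher number from compound 1 to compound 3 (1.00 log units; beyond the scatter) and a 10-fold lower number from compound 2 to compound 3 (1.00 log units; beyond the scatter). Compound 4 `Cc1ccc(S(=O)(=O)NCc2ccc(CNC(=O)c3ccccc3Cl)cc2)cc1` differs from compound 3 by 2-chlorophenyl in place of 4-chlorophenyl on a carbonyl carbon. Every measured step swaps one group for another at the same place on the ring, so none of them tells what moving the chlorine within the ring does. The measured steps themselves were a 100-fold higher number from compound 1 to compound 2 (2.00 log units; beyond the scatter) and a 10-fold higher number from compound 1 to compound 3 (1.00 log units; beyond the scatter), showing that this assay responds strongly to changes on this ring. Compound 4 is therefore expected to shift by a modest amount in an uncertain direction, estimated at a 3.0-fold higher number from compound 3 to compound 4 (0.48 log units; beyond the scatter). The estimate for compound 4 is 30 nM, with a range from 5 nM to 200 nM.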

Compound 4, effective concentration (reported as EC, without a stated level of effect): 10 nM
Beside the measured number, compound 4's estimate is 3.0-fold (0.48 log units) above it; the range from low to high includes it.
By their numbers in this assay, from the lowest: compound 1; then compounds 3 and 4 (each within the scatter of the next); then compound 2.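

In this assay, moving the chlorine on this ring leaves the reading in place (no change at the digits printed from compound 3 to compound 4 (within the scatter)), so 2-chlorophenyl and 4-chlorophenyl on the carbonyl carbon cannot be told apart here. Among these compounds, the change of group counts for more than this shift of the chlorine: compound 4 keeps the same distance from the other two as compound 3 (a 10-fold higher number from compound 1 to compound 4 (1.00 log units; beyond the scatter); a 10-fold lower number from compound 2 to compound 4 (1.00 log units; beyond the scatter)).

As far as these compounds go, whether the fluoro group of compound 1 would tolerate the same move remains open, as does the effect of an amine or a carboxylic acid on this ring. Nothing available offers an explanation for this result.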